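A few compounds are considered here, and "the series" means these few. Any claim that something is new, unique, unknown or untested is made for them only; others in the source may bear on it.

Measured compounds: compound 1 `CC(C)(C)OC(=O)N1CCC(OC2CCCC(Oc3ccc(S(C)(=O)=O)cc3)C2)CC1` gives > 100000 nM; compound 2 `CC(C)(C)OC(=O)N1CCC(O[C@H]2CC[C@@H](Oc3ccc(S(C)(=O)=O)cc3)CC2)CC1` gives 266 nM.

Compound 1 reaches only a limit of the assay in a functional assay on isolated protein for agonist activity at Glucose-dependent insulinotropic receptor (Homo sapiens), read by HTRF and cAMP accumulation (on this read-out lower numbers stand for an effect already at smaller amounts and higher numbers for an effect only at larger amounts of compound), as the limit of > 100000 nM in this assay, at which 1 of the 2 values shown sits, records. Among the measured compounds shown here, compound 2 is therefore the only compound with a number in this assay. Compound 3 `CC(C)(C)OC(=O)N1CCC(O[C@H]2CC[C@H](Oc3ccc(S(C)(=O)=O)cc3)CC2)CC1` is not yet measured; relative to compound 2 it shows (the two compounds have the same atoms and bonds and differ only in configuration as drawn: 2 of 2 stereo elements differ (all stereocentres are inverted: mirror images); a stereocentre at a saturated ring carbon is drawn s in compound 2 and r in compound 3; a stereocentre at a saturated ring carbon is drawn s in compound 2 and r in compound 3). For the measured compounds named here, no comparable pair of measured compounds exists here, so the size of this step rests on no measured precedent. Compound 3 is expected to give 1500 nM in this assay, between 200 nM and 20000 nM, which means an expected step of a 5.6-fold higher number from compound 2 to compound 3 (0.75 log units; beyond the scatter) toward larger amounts.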

Compound 3, half-maximal effective concentration: 16.1 nM
Estimate against measurement, compound 3: 93-fold (1.97 log units) above, and the stated range ends above it.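

Inverting both stereocentres at saturated ring carbons gives a 17-fold lower number from compound 2 to compound 3 (1.22 log units; beyond the scatter) in this assay. Among the compounds shown here, this is the first measured step in the set, and it shows that a large change in this read-out can arise with no atom or bond altered. Configuration alone accounts for the step: the fact that compounds 2 and 3 differ only in the configuration as drawn

The compounds shown do not separate the contributions of the two stereocentres. They also leave open whether this configuration keeps its advantage when a carboxylic acid stands in place of the sulfone.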